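Mirror Image of Compound 3: Expected Clearance in Liver Microsomes

A few compounds are considered here, and "the series" means these few. Any claim that something is new, unique, unknown or untested is made for them only; others in the source may bear on it.

Compound 3 `N#CC[C@]1(n2cc(-c3nc(-c4cn[nH]c4)cn4nccc34)cn2)C[C@H](C#N)C1` is the starting point. In an ADME assay on microsomes from liver (Homo sapiens) for pharmacokinetics (a lower number here means slower removal, a higher number faster removal of the compound), compound 3 gives 19 uL/min. That is the lowest of the two numbers measured here, and compound 2 `Cn1ccc(-c2cn3nccc3c(-c3cnn([C@]4(CC#N)C[C@H](C#N)C4)c3)n2)n1` sits closest to it, with compound 2 giving 23 uL/min, a gap that is within the scatter. Compound 1 `Cn1ccc(-c2cn3nccc3c(-c3cnn([C@]4(CC#N)C[C@@H](C#N)C4)c3)n2)n1` gives only a limit of the assay, < 8 uL/min.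

Compound 4 `N#CC[C@]1(n2cc(-c3nc(-c4cn[nH]c4)cn4nccc34)cn2)C[C@@H](C#N)C1` is the partner of compound 3: the two compounds have the same atoms and bonds and differ only in configuration as drawn: 2 of 2 stereo elements differ (all stereocentres are inverted: mirror images); a stereocentre at a saturated ring carbon is drawn r in compound 3 and s in compound 4; a stereocentre at a saturated ring carbon is drawn r in compound 3 and s in compound 4. The same kind of change has been measured once, between compound 1 and compound 2, which also differ only in configuration (the fact that compounds 1 and 2 differ only in the configuration as drawn). There the number rose, an at least 2.8-fold higher number from compound 1 to compound 2 (0.45 log units; beyond the scatter), although the size of that step is itself uncertain because compound 1 sits at a limit (the limit of < 8 uL/min in this assay, at which 1 of the 3 values shown sits). Compound 3 also differs from compound 1 by an at least 2.3-fold higher number from compound 1 to compound 3 (0.37 log units; beyond the scatter), so the two series need not move alike.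

On this evidence compound 4 is expected to show a higher number than compound 3, a 1.8-fold higher number from compound 3 to compound 4 (0.27 log units; within the scatter), a modest step. Compound 4 is therefore estimated at 35 uL/min, with a plausible range from 15 uL/min to 80 uL/min.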

Compound 4, intrinsic clearance in a liver preparation (reported as CLH), per the amount of preparation that the assay uses in the Homo sapiens assay: 44 uL/min
Beside the measured number, compound 4's estimate is 1.3-fold (0.10 log units) below it; the range from low to high includes it.
By their numbers in the Homo sapiens assay, from the lowest: compounds 3, 2 and 4 (each within the scatter of the next, the first and the last beyond it). At a limit, below all of these: compound 1.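

In the Homo sapiens assay the mirror-image change now gives a step between two real numbers, a 2.3-fold higher number from compound 3 to compound 4 (0.36 log units; beyond the scatter), in the same direction as the rise from compound 1 to compound 2, which rested on a limit. With this configuration, 1H-pyrazol-4-yl in place of 1-methyl-1H-pyrazol-3-yl gives a 1.9-fold higher number from compound 2 to compound 4 (0.28 log units; within the scatter), and the comparison with the other configuration stays unsettled: the same change on two cores in the Homo sapiens assay, an at least 2.3-fold higher number (0.37 log units; beyond the scatter) from compound 1 to compound 3 and a 1.9-fold higher number (0.28 log units; within the scatter) from compound 2 to compound 4; the limit leaves it open whether they differ. In a physicochemical assay for lipophilicity, using the shake flask method, in phosphate buffer, measured as octanol-water partition, at pH 7.4 (on this read-out higher numbers stand for higher lipophilicity and lower numbers for lower lipophilicity), compound 3 gives 1.7 and compound 4 gives 1.6, a step (a number 0.10 log units lower from compound 3 to compound 4 (within the scatter)) that does not separate the two compounds.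

From the compounds shown here alone, the true size of the inversion step between compound 1 and compound 2 stays open: the limit of < 8 uL/min in the Homo sapiens assay, at which 1 of the 4 values shown sits. Going by these compounds, whether the rise on inversion persists with an amine or a carboxylic acid in place of the pyrazole group also stays open.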